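The compounds below may be only part of what the source reports. "The series", "measured", "known", "first", "only" and "open" are said of these compounds alone.

Measured so far in a functional assay on HT cells (Homo sapiens) for antiproliferative activity, read by fluorescence, with a stated time of 72 h; a lower number here means a stronger inhibitor of growth, a higher number a weaker inhibitor of growth:
compound 1 `CC(C)c1n[nH]c2c(NCc3ccc(-c4ccccn4)cc3)nc(SC(CO)C(C)C)nc12`: 980 nM
compound 2 `CC(C)c1n[nH]c2c(NCc3ccc(-c4ccccn4)cc3)nc(SC3CCCC3O)nc12`: 567 nM

For the measured compounds named here, compound 1 gives the higher of the two numbers, with compound 2 the only neighbour; that step, a 1.7-fold lower number from compound 1 to compound 2 (0.24 log units; within the scatter), stays within the scatter. Compound 3 `CCC(O)CSc1nc(NCc2ccc(-c3ccccn3)cc2)c2[nH]nc(C(C)C)c2n1` differs from compound 1 by 2-hydroxybutyl in place of 1-(hydroxymethyl)-2-methylpropyl on a sulfur. Going by the values given here, the only step that bears on it is the exchange of another hydroxyalkyl group on the same sulfur, from compound 1 to compound 2, which did not move the number beyond the scatter. A step of similar size, a 1.2-fold lower number from compound 1 to compound 3 (0.09 log units; within the scatter), is therefore expected. Compound 3 is estimated at 800 nM, within 350 nM to 1800 nM.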

Compound 3, concentration for 50% growth inhibition: 273 nM
Compound 3: middle estimate off by 2.9-fold (0.47 log units), on the high side; the measured number lies below the stated range.
By their numbers in this assay, from the lowest: compound 3; then compounds 2 and 1 (each within the scatter of the next).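

The exchange of one hydroxyalkyl group for another on this sulfur can move the number beyond the scatter, with a 3.6-fold lower number from compound 1 to compound 3 (0.56 log units; beyond the scatter) and a 2.1-fold lower number from compound 2 to compound 3 (0.32 log units; beyond the scatter) in this assay when 2-hydroxybutyl enters. Among the three compounds, the unbranched-at-sulfur, ring-free 2-hydroxybutyl of compound 3 gives the lowest number, a difference that the earlier step did not reveal.

Open, on these data alone, is whether an amine, a carboxylic acid or a longer chain on this sulfur would hold that gain. Nothing at hand explains these steps.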